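Aryl selenocyanate carbamates: methoxy to chloro on the aryl ester

The compounds below may be only part of what the source reports. "The series", "measured", "known", "first", "only" and "open" are said of these compounds alone.

Compound 1 `COc1ccc(OC(=O)Nc2ccc([Se]C#N)cc2)cc1` is the starting point. In a functional assay on MCF7 cells (Homo sapiens) for cytotoxicity, read by MTT assay, with a stated time of 72 h (a lower number here means a stronger inhibitor of growth, a higher number a weaker inhibitor of growth), compound 1 gives 48200 nM, the highest of the two numbers recorded so far. Among the measured compounds shown here, the only other measured compound, compound 2 `CCCCOC(=O)Nc1ccc([Se][Se]c2ccc(NC(=O)OCCCC)cc2)cc1`, gives 46300 nM in this assay; the two values lie within the scatter of each other, so neither compound can be said to inhibit growth more strongly than the other. For the measured compounds named here, no step between measured compounds that differ in a single place is available, so nothing is yet known about how any one replacement moves the number.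

Compound 3 `N#C[Se]c1ccc(NC(=O)Oc2ccc(Cl)cc2)cc1` has not been measured. It differs from compound 1 in one place: chloro in place of methoxy on an aromatic carbon, on an aromatic carbon of a six-membered aromatic ring of carbon only. Going by the values given here, with no comparable step recorded, the expected step of a 1.1-fold lower number from compound 1 to compound 3 (0.03 log units; within the scatter) is no change beyond the scatter, in either direction. Compound 3 is accordingly expected to give about 45000 nM in this assay, within a range from 18000 nM to 110000 nM.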

Compound 3, concentration for total growth inhibition: 26300 nM
Estimate against measurement, compound 3: 1.7-fold (0.23 log units) above, and the stated range covers the measured number.
By their numbers in this assay, from the lowest: compounds 3, 2 and 1 (each within the scatter of the next).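

In this assay, chloro in place of methoxy on an aromatic carbon, para to a large group, gives a 1.8-fold lower number from compound 1 to compound 3 (0.26 log units; within the scatter), the first single-place step available in this series. At this position, exchanging methoxy, with its 2 heavy atoms and 1 hydrogen-bond acceptor, for chloro, with 1 heavy atom and no hydrogen-bond acceptor, therefore produces no change beyond the scatter in this read-out, although one step cannot define a trend for the position. No measured evidence bearing on the origin of this step is at hand.

On these data alone, whether a larger departure from methoxy at this position, such as an amine, a carboxylic acid or a longer alkoxy chain, would move the number beyond the scatter remains open. Compound 2 differs from compound 1 in more than one place, so the separate contributions of the selenocyanate, the diselenide and the butyl chain also remain unresolved.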